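This account rests on a few compounds, and the source may have more. Where it says the series, first, only, none or still open, it means among the compounds named here.

Measured so far:
compound 1 `CC(=O)OCc1ccc2oc(=O)c(C(=O)Sc3cccc(Cl)c3)cc2c1` gives 65.8%
compound 2 `CCC(=O)OCc1ccc2oc(=O)c(C(=O)Oc3cccc(Br)c3)cc2c1` gives 40.2%

Both numbers come from a functional assay on HT-1080 cells (Homo sapiens), read by transwell migration, with a stated time of 24 h, tested at 1 uM; on this read-out lower numbers stand for a stronger effect and higher numbers for a weaker effect at the one concentration tested. Compound 2 stands lowest of the two, and its nearest neighbour, compound 1, lies higher by a margin beyond the usual scatter. Going by the values given here, no two measured compounds differ in one place, so the size of a single step in this assay is not yet known. Compound 3 `CC(C)(C)C(=O)OCc1ccc2oc(=O)c(C(=O)Oc3cccc(Br)c3)cc2c1` differs from compound 2 by tert-butyl in place of ethyl on a carbonyl carbon. For this change a step within the scatter is expected, with no set direction. Compound 3 is expected to give 42%, between 25% and 60%. That expectation amounts to a step of a number 1.8 percentage points higher from compound 2 to compound 3 (within the scatter).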

Compound 3, a percentage reported as activity, at one concentration (the size of the read-out at that concentration, not a potency): 48.2%
Compound 3: middle estimate off by 6.2 percentage points, on the low side; low and high end bracket the measured number.
By their numbers in this assay, from the lowest: compounds 2 and 3 (each within the scatter of the next); then compound 1.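

In this assay, the series now has its first single-place step, on a carbonyl carbon: tert-butyl in place of ethyl gives a number 8 percentage points higher from compound 2 to compound 3 (within the scatter). At this place, then, the exchange of these two groups does not separate compound 2 and compound 3. No measurement at hand speaks to the reason for this result.

Going by these compounds, whether a longer chain or an amine-bearing chain on this carbonyl carbon would also stay within the scatter remains open. The thioester and the chloro group of compound 1 also remain unresolved as single changes.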